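The source may hold more compounds than are shown below. What is called first, only, known or untested is meant among the compounds shown, and "the series" means these compounds.

Measured compounds:
compound 1 `CCN(CC)CCNc1cc(C)c2cc(NC(=O)c3ccc(Cl)c(Cl)c3)ccc2n1` — 1420 nM
compound 2 `CCc1ccccc1C(=O)Nc1ccc2nc(N3CCN(CC)CC3)cc(C)c2c1` — 15800 nM

In a functional assay on MCF7 cells (Homo sapiens) for antiproliferative activity, read by MTT assay, with a stated time of 72 h (on this read-out lower numbers stand for stronger inhibition and higher numbers for weaker inhibition), compound 2 gives the higher of the two numbers; compound 1 sits well below it, and the gap between them lies beyond the scatter. For the measured compounds named here, the two share a core but differ in more than one place, so no single step connects them.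

Compound 3 `CCN1CCN(c2cc(C)c3cc(NC(=O)c4cccnc4)ccc3n2)CC1` carries pyridin-3-yl in place of 2-ethylphenyl on a carbonyl carbon. Nothing measured here isolates that change, so the step from compound 2 to compound 3 is expected to stay small, a 1.6-fold lower number from compound 2 to compound 3 (0.20 log units; within the scatter), likely within the scatter or a modest decrease. Compound 3 is thus estimated at 10000 nM, with a range from 3000 nM to 40000 nM.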

Compound 3, half-maximal inhibitory concentration: 26600 nM
Beside the measured number, compound 3's estimate is 2.7-fold (0.42 log units) below it; the measured number falls inside the stated range.
By their numbers in this assay, from the lowest: compound 1; then compounds 2 and 3 (each within the scatter of the next).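

In this assay, pyridin-3-yl in place of 2-ethylphenyl on a carbonyl carbon gives a 1.7-fold higher number from compound 2 to compound 3 (0.23 log units; within the scatter) and so stays within the scatter. At this position, then, the read-out does not separate a carbon-only aromatic ring bearing an ethyl group from an aromatic ring with one hetero atom. Nothing available bears on this result.

From the compounds shown here alone, it remains open how a pyridin-4-yl, a cyclohexyl or a carboxylic acid on that carbonyl carbon would read. Compound 1 differs from both compounds in more than one place, and its number cannot be tied to any one group.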